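This account rests on a few compounds, and the source may have more. Where it says the series, first, only, none or still open, it means among the compounds named here.

Measured so far:
compound 1, `O=C(/C=C\N(O)Cc1ccccc1)c1ccc([N+](=O)[O-])cc1` — in an assay on RBL-1 cells for inhibition of Polyunsaturated fatty acid 5-lipoxygenase (Rattus norvegicus) (a higher number here means a weaker inhibitor, a lower number a stronger inhibitor), compound 1 gives 2500 nM
compound 2, `CC(=O)ON(/C=C\C(=O)c1ccc([N+](=O)[O-])cc1)Cc1ccccc1` — in this assay compound 2 gives only a limit, > 25000 nM

Among the measured compounds shown here, compound 2 stands at the top of the pair; the one measured step, an at least 10-fold higher number from compound 1 to compound 2 (1.00 log units; beyond the scatter), acetyl in place of hydrogen on an oxygen, ends at the limit of > 25000 nM in this assay, at which 1 of the 2 values shown sits. Compound 3, `CC(=O)ON(/C=C\C(=O)c1ccc(Cl)cc1)Cc1ccccc1`, differs from compound 2 by chloro in place of nitro on an aromatic carbon. For the measured compounds named here, no measured step covers that change, so the only guide is that compound 2 already sits at the limit. Compound 3 is expected to show no step beyond the scatter, a step that the limit leaves unreadable from compound 2 to compound 3. Compound 3 is estimated at 40000 nM, within 10000 nM to 160000 nM.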

Compound 3, half-maximal inhibitory concentration: > 25000 nM
Compound 3: no number, only a limit; the forecaster's own chance of this, stated with the estimate: 70%; the middle value is on the limit's open side.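

Compound 2 and compound 3 both give only a limit in this assay, so no step between them can be read: the limit of > 25000 nM in this assay, at which 2 of the 3 values shown sit.

From the compounds shown here alone, what chloro in place of nitro on an aromatic carbon does to inhibition stays open.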